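Inverting Two Chain Stereocentres in a Weak Macrolide Analogue

The source may hold more compounds than are shown below. What is called first, only, known or untested is meant among the compounds shown, and "the series" means these compounds.

Measured so far in a functional assay on MCF7 cells (Homo sapiens) for cytotoxicity; a higher number here means a weaker inhibitor, a lower number a stronger inhibitor:
compound 1, `C=C/C=C\[C@H](C)[C@H](OC(N)=O)[C@@H](C)[C@H](O)[C@@H](C)/C=C(\C)[C@H]1[C@H](C)[C@@H](O)[C@@H](C)[C@@H]1/C=C/C[C@@H]1OC(=O)[C@H](C)[C@@H](O)[C@H]1C`, gives 2100 nM
compound 2, `C=C/C=C\[C@H](C)[C@H](OC(N)=O)[C@@H](C)[C@H](O)[C@@H](C)CC(=C)[C@H]1[C@H](C)[C@@H](O)[C@@H](C)[C@@H]1/C=C/C[C@@H]1OC(=O)[C@H](C)[C@@H](O)[C@H]1C`, gives 130 nM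
compound 3, `C=C/C=C\[C@H](C)[C@H](OC(N)=O)[C@@H](C)[C@H](O)[C@@H](C)C[C@@](C)(O)[C@H]1[C@H](C)[C@@H](O)[C@@H](C)[C@@H]1/C=C/C[C@@H]1OC(=O)[C@H](C)[C@@H](O)[C@H]1C`, gives 2360 nM

Among these three, compound 3 carries the highest number in this assay. Its nearest neighbour is compound 1, which lies within the scatter of it, so no order can be read between compound 1 and compound 3. Compound 2 stands well apart, with a number beyond the scatter below that of compound 3. Among the compounds with values here, no step between measured compounds is available for a pair that differs in a single place, so nothing has been learned yet about how a single change moves the number.

Compound 4, `C=C/C=C\[C@H](C)[C@H](OC(N)=O)[C@@H](C)[C@H](O)[C@H](C)C[C@](C)(O)[C@H]1[C@H](C)[C@@H](O)[C@@H](C)[C@@H]1/C=C/C[C@@H]1OC(=O)[C@H](C)[C@@H](O)[C@H]1C`, is the next compound to be examined. Compared with compound 3, (the two compounds have the same atoms and bonds and differ only in configuration as drawn: 2 of 17 stereo elements differ; a stereocentre at a saturated chain carbon is drawn S in compound 3 and R in compound 4; a stereocentre at a saturated chain carbon is drawn R in compound 3 and S in compound 4). Within the data shown here, with no comparable step on record, the size of this move in this assay cannot be anchored; it is expected to be modest, possibly none beyond the scatter, in either direction. On that basis compound 4 is expected to give 3000 nM, within 600 nM to 15000 nM, an estimated step of a 1.3-fold higher number from compound 3 to compound 4 (0.10 log units; within the scatter).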

Compound 4, half-maximal inhibitory concentration: 7350 nM
For compound 4 the middle estimate is 2.5-fold (0.39 log units) below the measured one; measured number inside the range.
By their numbers in this assay, from the lowest: compound 2; then compounds 1 and 3 (each within the scatter of the next); then compound 4.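

In this assay, redrawing two stereocentres at saturated chain carbons, one from S to R and the other from R to S, gives a 3.1-fold higher number from compound 3 to compound 4 (0.49 log units; beyond the scatter). Within the data shown here, this is the first step on record between two compounds that can be set directly side by side, and it shows that this part of the chain responds to configuration, with the number rising beyond the scatter. No atom or bond has to be invoked for this move, because the change is one of stereochemistry alone: the fact that compounds 3 and 4 differ only in the configuration as drawn

The two stereocentres change together, so the compounds shown leave open whether one of them accounts for the step or both contribute to it. Also open, from the compounds shown here alone, is how the number would respond to this same change of configuration if an amine or a methoxy group stood in place of a hydroxyl group.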